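A few compounds are considered here, and "the series" means these few. Any claim that something is new, unique, unknown or untested is made for them only; others in the source may bear on it.

Measured compounds:
compound 1 `CN(C)CCn1ccc2cc(NS(=O)(=O)c3cccc4ccccc34)ccc21` gives 94.2 nM
compound 2 `Cc1cc2cc(NS(=O)(=O)c3cccc4ccccc34)ccc2n1CCN(C)C` gives 124 nM
compound 3 `Cc1c(S(=O)(=O)Nc2ccc3ccn(CCN(C)C)c3c2)sc2ccc(Cl)cc12` gives 90.2 nM

Of the compounds shown here, three from this series have been tested in an assay on HEK293 cells for binding affinity to 5-hydroxytryptamine receptor 6 (Homo sapiens); a higher number here means a weaker inhibitor, a lower number a stronger inhibitor. Compound 1 and compound 2 share one core and differ in a single place: methyl in place of hydrogen on an aromatic carbon. That change moved the number by a 1.3-fold higher number from compound 1 to compound 2 (0.12 log units; within the scatter), so the two values sit together and neither compound can be called stronger or weaker than the other.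

Compound 3 carries a different sulfonamide part; how its core differs from the core of compound 1 is not broken down here. Its value in this assay falls alongside those of compound 1 and compound 2, all three within the scatter of one another.

Compound 4 `Cc1c(S(=O)(=O)Nc2ccc3cc(C)n(CCN(C)C)c3c2)sc2ccc(Cl)cc12` has not yet been measured. It is related to compound 3 by the same change that relates compound 2 to compound 1: methyl in place of hydrogen on an aromatic carbon. The words describing the place of the change are identical in both pairs, so it is the same change on the second core.

Because the earlier step, a 1.3-fold higher number from compound 1 to compound 2 (0.12 log units; within the scatter), stayed within the scatter, compound 4 is expected to land close to compound 3, with a step of about a 1.2-fold higher number from compound 3 to compound 4 (0.09 log units; within the scatter) expected in this assay. The estimate for compound 4 is 110 nM, expected to fall between 45 nM and 260 nM. This expectation rests on one prior example only, so it is held loosely.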

Compound 4, inhibition constant: > 1000 nM
Compound 4: a limit, no number; the forecaster's own chance of this, stated with the estimate: 2%; middle value at least 9.0-fold (0.95 log units) away from the limit.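

In this assay compound 4 gives > 1000 nM, which is a limit of the assay and not a number. On the core of compound 3, methyl in place of hydrogen on an aromatic carbon gave an at least 11-fold higher number from compound 3 to compound 4 (1.04 log units; beyond the scatter), so in this series the step seen on one core did not carry over to the other: the same change on two cores in this assay, a 1.3-fold higher number (0.12 log units; within the scatter) from compound 1 to compound 2 and an at least 11-fold higher number (1.04 log units; beyond the scatter) from compound 3 to compound 4, at least 8.4-fold (0.92 log units) apart, beyond the scatter of two such steps. For the compounds shown here, this comparison rests on only two pairs, and it does not show which difference between the core of compound 1 and the core of compound 3 sets the two steps apart, how large the step on the core of compound 3 really is, or why it is so much larger there.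

The compounds shown leave open whether the large step on the core of compound 3 is specific to methyl, or whether ethyl or fluorine on the same aromatic carbon would give a similar result. They also leave open whether the step would stay as large on that core if a 3-(dimethylamino)propyl group stood in place of the 2-(dimethylamino)ethyl group.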